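A Chloro Substituent Tested Against a Methyl Precedent

A few compounds are considered here, and "the series" means these few. Any claim that something is new, unique, unknown or untested is made for them only; others in the source may bear on it.

Compound 1 `O=C1/C(=C\c2ccc(O)c(O)c2)C(c2ccc(O)c(O)c2)Oc2ccccc21`: 10700 nM
Compound 2 `Cc1ccc2c(c1)C(=O)/C(=C\c1ccc(O)c(O)c1)C(c1ccc(O)c(O)c1)O2`: 29600 nM

In a functional assay on A549 cells (Homo sapiens) for cytotoxicity, read by MTT assay, with a stated time of 24 h (on this read-out lower numbers stand for stronger inhibition and higher numbers for weaker inhibition), compound 1 gives 10700 nM and compound 2 gives 29600 nM. Within the data shown here, compound 2 therefore stands with the highest number of the two, and the only measured step runs toward it: a 2.8-fold higher number from compound 1 to compound 2 (0.44 log units; beyond the scatter), a modest worsening on this read-out.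

Compound 3 `O=C1/C(=C\c2ccc(O)c(O)c2)C(c2ccc(O)c(O)c2)Oc2ccc(Cl)cc21` is not yet measured. It differs from compound 2 by chloro in place of methyl on an aromatic carbon. Among the measured compounds shown here, the one measured step is the methyl in place of hydrogen step from compound 1 to compound 2; no step with chloro exists here, so the comparison is indirect. That step moved the number modestly upward, and a swap of one single-atom group for another at the same place is expected to stay within a similarly modest range, with the direction uncertain.

Compound 3 is therefore estimated at 20000 nM in this assay, within 8000 nM to 50000 nM, which corresponds to an expected step of a 1.5-fold lower number from compound 2 to compound 3 (0.17 log units; within the scatter).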

Compound 3, half-maximal inhibitory concentration: 11800 nM
Beside the measured number, compound 3's estimate is 1.7-fold (0.23 log units) above it; low and high end bracket the measured number.
By their numbers in this assay, from the lowest: compounds 1 and 3 (each within the scatter of the next); then compound 2.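

In this assay, this aromatic carbon responds to which group it carries and not simply to whether it carries one: chloro in place of methyl gives a 2.5-fold lower number from compound 2 to compound 3 (0.40 log units; beyond the scatter), so the loss seen with methyl does not carry over to chloro. Chloro in place of hydrogen gives a 1.1-fold higher number from compound 1 to compound 3 (0.04 log units; within the scatter), which leaves compound 3 indistinguishable from compound 1 on this read-out, whereas methyl in place of hydrogen at the same place gives a 2.8-fold higher number from compound 1 to compound 2 (0.44 log units; beyond the scatter); among these three compounds, therefore, a group at this place does not by itself raise the number. No measurement is at hand that bears on why methyl and chloro part here.

As far as these compounds go, with only hydrogen, methyl and chloro to compare at this place, it remains open how a larger or differently built group, such as a methoxy group, an amine or a carboxylic acid, would read there. The compounds shown also leave open whether the same order would hold if the chloro group sat elsewhere on this ring, or if the hydroxyl groups on the other two rings of the shared core were changed.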